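Solubility along a urea series: from methylsulfanyl to tert-butyl

The source may hold more compounds than are shown below. What is called first, only, known or untested is meant among the compounds shown, and "the series" means these compounds.

Measured compounds:
- Compound 1, `Cc1cc(NC(=O)Nc2ccc(O)cc2)c2ccccc2n1`: 100 nM
- Compound 2, `CSc1ccc(NC(=O)Nc2cc(C)nc3ccccc23)cc1`: 1300 nM

In a physicochemical assay for solubility, at pH 7.4 (on this read-out higher numbers stand for higher solubility and lower numbers for lower solubility), compound 2 gives 1300 nM, the highest of the two numbers shown; its nearest neighbour is compound 1, which gives 100 nM. For the measured compounds named here, the single measured step, a 13-fold higher number from compound 1 to compound 2 (1.11 log units; beyond the scatter), joins these two values.

Compound 3, `Cc1cc(NC(=O)Nc2ccc(C(C)(C)C)cc2)c2ccccc2n1`, has not yet been measured in this assay. It differs from compound 2 in one place: tert-butyl in place of methylsulfanyl on an aromatic carbon. Going by the values given here, no measured step replaces methylsulfanyl with tert-butyl, so the only step in hand, a 13-fold higher number from compound 1 to compound 2 (1.11 log units; beyond the scatter), bears on it indirectly: it shows that a change at this same position, para to a large group, can move the number by a large amount. The group that leaves carries one hydrogen-bond acceptor and the one that enters carries none, and the count of heavy atoms grows, so a step of moderate size in the downward direction is expected, a 2.6-fold lower number from compound 2 to compound 3 (0.41 log units; beyond the scatter). Compound 3 is therefore estimated at 500 nM, with a range from 150 nM to 2000 nM.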

Compound 3, solubility: 6200 nM
Estimate against measurement, compound 3: 12-fold (1.09 log units) below; measured number outside the range, above it.
By their numbers in this assay, from the lowest: compound 1; then compound 2; then compound 3.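

In this assay, the replacement of methylsulfanyl by tert-butyl on the aromatic carbon para to a large group gives a further rise in the number (a 4.8-fold higher number from compound 2 to compound 3 (0.68 log units; beyond the scatter)), so the increase seen earlier is not the limit of what this position allows. Across the wider change from hydroxy to tert-butyl, the span at this one position becomes larger still (a 62-fold higher number from compound 1 to compound 3 (1.79 log units; beyond the scatter)), and the three compounds now stand in a single order, with tert-butyl, the group with more heavy atoms than methylsulfanyl and no hydrogen-bond acceptor, at the top. Nothing at hand gives a measured property that would account for this order, so the result stands as an observation about these three groups alone.

What the compounds shown leave open is whether an amine, a carboxylic acid or a longer alkyl chain at this same place would fall within the span of these three groups or outside it. They also leave open whether the same order of hydroxy, methylsulfanyl and tert-butyl would hold at any other position of the shared core.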